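The source may hold more compounds than are shown below. What is called first, only, known or untested is meant among the compounds shown, and "the series" means these compounds.

Measured so far in an ADME assay on HEp-2 cells (Homo sapiens) for cytotoxicity, read by trypan blue exclusion, with a stated time of 24 h; on this read-out higher numbers stand for lower toxicity in this test and lower numbers for higher toxicity in this test
Compound 1 `C/C(=N/N=C1\SCC(=O)N1Cc1ccc(F)cc1)c1ccccn1` gives 16 ug/mL
Compound 2 `C/C(=N\N=C1/SCC(=O)N1Cc1cccc(Cl)c1)c1ccccn1` gives 21 ug/mL

Among the compounds with values here, compound 1 at 16 ug/mL and compound 2 at 21 ug/mL lie within the scatter of each other, so compound 1 stands level with the only other measured compound.

Still unmeasured is compound 3 `C/C(=N/N=C1\SCC(=O)N1Cc1ccc(F)cc1)c1cccs1` with the change thiophen-2-yl in place of pyridin-2-yl on a carbon with a double bond to nitrogen in which thiophen-2-yl stands in place of pyridin-2-yl on a carbon with a double bond to nitrogen. Within the data shown here, the series holds no measured step between compounds that differ in one place, so nothing sizes this exchange directly. In this assay no step beyond the scatter is expected, with only a slight lean toward a higher number. The estimated move is a 1.3-fold higher number from compound 1 to compound 3 (0.10 log units; within the scatter) and it is expected to stay small. The expectation takes compound 1 at 16 ug/mL as its starting point. Among the measured compounds shown here, the range is kept wide, as the series offers no precedent for this exchange. For compound 3 the expected value is 20 ug/mL with an estimated range from 8 ug/mL to 50 ug/mL on the same read-out.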

Compound 3, half-maximal cytotoxic concentration in the HEp-2 assay: 15 ug/mL
Compound 3: middle estimate off by 1.3-fold (0.12 log units), on the high side, and the stated range covers the measured number.
By their numbers in the HEp-2 assay, from the lowest: compounds 3, 1 and 2 (each within the scatter of the next).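

Within the data shown here, at the carbon with a double bond to nitrogen, thiophen-2-yl in place of pyridin-2-yl gives the first one-place reading: in the HEp-2 assay the exchange gives a 1.1-fold lower number from compound 1 to compound 3 (0.03 log units; within the scatter) and stays within the scatter, so a six-membered aromatic ring with 1 hetero atom and a five-membered one are not told apart at this position on this read-out. In a physicochemical assay, with a stated time of 30 min (on this read-out higher numbers stand for weaker inhibition and lower numbers for stronger inhibition), the same exchange gives a 1.3-fold higher number from compound 1 to compound 3 (0.12 log units; within the scatter) on the same pair, so the physicochemical assay also shows no step beyond the scatter, with compound 1 at 16200000 nM and compound 3 at 21500000 nM in that test. No measured finding is available that accounts for this lack of separation.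

The compounds shown leave open whether a plain phenyl ring, an amine or a carboxylic acid on this carbon would move either read-out beyond the scatter. They also leave open whether the same exchange would give a comparably small step on the core of compound 2.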